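This account rests on a few compounds, and the source may have more. Where it says the series, first, only, none or still open, it means among the compounds named here.

Compound 1 `Cn1cc(/C=C2/C(=O)Nc3ccccc32)c2cc(Nc3nccc(-c4ccccc4)n3)ccc21`: 42900 nM in a functional assay on MCF7 cells (Homo sapiens) for cytotoxicity, read by MTT assay, with a stated time of 48 h; on this read-out lower numbers stand for stronger inhibition and higher numbers for weaker inhibition.
Compound 2 `Cn1cc(/C=C2/C(=O)Nc3ccccc32)c2cc(Nc3nccc(-c4ccc(C(F)(F)F)cc4)n3)ccc21`: 65200 nM.
Compound 3 `Cn1cc(/C=C2/C(=O)Nc3ccccc32)c2cc(Nc3nccc(-c4ccc(Cl)cc4Cl)n3)ccc21`: > 100000 nM, a limit of the assay and not a number.

Compound 3 thus stands at the upper edge of the measured values, at the limit of > 100000 nM in this assay, at which 1 of the 3 values shown sits. The step of an at least 2.3-fold higher number from compound 1 to compound 3 (0.36 log units; beyond the scatter) lies beyond the scatter, whereas an at least 1.5-fold higher number from compound 2 to compound 3 (0.18 log units; that floor lies within the scatter) has a floor within it. Compound 4 `Cn1cc(/C=C2/C(=O)Nc3ccccc32)c2cc(Nc3nccc(-c4cccs4)n3)ccc21` differs from compound 3 by thiophen-2-yl in place of 2,4-dichlorophenyl on an aromatic carbon. For the measured compounds named here, the change removes the 2,4-dichlorophenyl whose arrival gave an at least 2.3-fold higher number from compound 1 to compound 3 (0.36 log units; beyond the scatter), and no measured step covers thiophen-2-yl itself. The number for compound 4 in this assay is therefore expected to fall, a step of an at least 2.0-fold lower number from compound 3 to compound 4 (0.30 log units; that floor lies within the scatter). Compound 4 is estimated at 50000 nM, between 20000 nM and 150000 nM.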

Compound 4, half-maximal inhibitory concentration: 30800 nM
Compound 4: the middle estimate sits 1.6-fold (0.21 log units) above what was measured, and the stated range covers the measured number.
By their numbers in this assay, from the lowest: compounds 4, 1 and 2 (each within the scatter of the next, the first and the last beyond it). At a limit, above all of these: compound 3.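

In this assay, a five-membered aromatic ring with a sulfur atom at this position holds level with phenyl, with a 1.4-fold lower number from compound 1 to compound 4 (0.14 log units; within the scatter). The same ring also separates from both substituted phenyl groups, with a 2.1-fold lower number from compound 2 to compound 4 (0.33 log units; beyond the scatter) and an at least 3.2-fold lower number from compound 3 to compound 4 (0.51 log units; beyond the scatter). The last of these steps is only a floor, since compound 3 stands at a limit and not at a number: the limit of > 100000 nM in this assay, at which 1 of the 4 values shown sits.

Open remains what an amine such as morpholine or a carboxylic acid would give at this position. Also open, as far as these compounds go, is whether furan-2-yl would behave like thiophen-2-yl.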